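From propargyl to 2,2-dimethoxyethyl in compound 3

The compounds below may be only part of what the source reports. "The series", "measured", "known", "first", "only" and "open" are said of these compounds alone.

Measured in a functional assay on MCF7 cells (Homo sapiens), read by MTT assay, with a stated time of 48 h; on this read-out higher numbers stand for weaker inhibition and lower numbers for stronger inhibition:
Compound 1 `CCN(CC)CCCNC(=O)c1ccc(C(CC)(CC)c2ccc(OCC(O)C(C)(C)C)c(C)c2)n1CC`: 190 nM
Compound 2 `C#CCNC(=O)c1ccc(C(CC)(CC)c2ccc(OCC(O)C(C)(C)C)c(C)c2)n1CC`: > 50000 nM
Not yet measured:
Compound 3 `CCn1c(C(=O)NCC(OC)OC)ccc1C(CC)(CC)c1ccc(OCC(O)C(C)(C)C)c(C)c1`

Compound 2 gives > 50000 nM, which is a limit of the assay and not a number. That places compound 2 at the limit of > 50000 nM in this assay, at which 1 of the 2 values shown sits.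

Compound 3 differs from compound 2 by a single change: dimethoxymethyl in place of ethynyl on a saturated chain carbon bound to an amide-type nitrogen. In words, dimethoxymethyl stands in place of ethynyl on a saturated chain carbon bound to an amide-type nitrogen, so that propargylcarbamoyl becomes (2,2-dimethoxyethyl)carbamoyl.

Among the measured compounds shown here, the one measured step at this place is an at least 260-fold higher number from compound 1 to compound 2 (2.42 log units; beyond the scatter), with ethynyl in place of 2-(diethylamino)ethyl. It is large. Compound 3, like compound 2, lacks the 2-(diethylamino)ethyl group, so a return towards compound 1 at 190 nM is not expected.

The expected step is an at least 1.1-fold lower number from compound 2 to compound 3 (0.04 log units; that floor lies within the scatter), which would be none beyond the scatter in this assay. For compound 3 the estimated value is 45000 nM, with an expected range from 12000 nM to 100000 nM.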

Compound 3, half-maximal inhibitory concentration: > 50000 nM
Compound 3 was reported as a limit; the forecaster's own chance of this, stated with the estimate: 65%; middle value at least 1.1-fold (0.04 log units) away from the limit.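

In this assay compound 3 gives > 50000 nM, which is a limit of the assay and not a number. Dimethoxymethyl carries hydrogen-bond acceptors where ethynyl carries none, yet this second replacement of 2-(diethylamino)ethyl gives an at least 260-fold higher number from compound 1 to compound 3 (2.42 log units; beyond the scatter), so the large loss on this saturated chain carbon bound to an amide-type nitrogen is not tied to ethynyl alone. The step between compound 2 and compound 3 cannot be read, as both values are limits, and the two compounds stand together at the end of the assay's range: the limit of > 50000 nM in this assay, at which 2 of the 3 values shown sit.

From the compounds shown here alone, what remains open is which feature of the chain in compound 1 goes with its measurable value, as only compound 1 among the three carries an amine there, and the chains also differ in length and in the groups they bear. A shorter chain ending in a dimethylamino group, a longer chain ending in a diethylamino group, or a chain ending in a carboxylic acid could begin to separate the amine from the length of the chain.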